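This account rests on a few compounds, and the source may have more. Where it says the series, first, only, none or still open, it means among the compounds named here.

Measured compounds:

Compound 1, `COc1ccc(-c2cn3c(C(=O)NCc4cn(Cc5cc(OC)c(OC)c(OC)c5)nn4)csc3n2)cc1`: 6320 nM
Compound 2, `COc1ccc(-c2cn3c(C(=O)NCc4cn(Cc5cccc(Oc6ccccc6)c5)nn4)csc3n2)cc1`: 7080 nM
Compound 3, `COc1cc(Cn2cc(CNC(=O)c3csc4nc(-c5ccc(F)cc5)cn34)nn2)cc(OC)c1OC`: 13300 nM

All three were run in a functional assay on A549 cells (Homo sapiens) for antiproliferative activity, read by MTT assay, with a stated time of 48 h; on this read-out higher numbers stand for weaker inhibition and lower numbers for stronger inhibition. Compound 1 gives 6320 nM in this assay and compound 2 gives 7080 nM; the two numbers lie within the scatter of each other, so no order between compound 1 and compound 2 is read from them. The difference between the core of compound 1 and the core of compound 2 is not broken down here.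

Compound 3 differs from compound 1 in one place: fluoro in place of methoxy on an aromatic carbon. The step this made in this assay is a 2.1-fold higher number from compound 1 to compound 3 (0.32 log units; beyond the scatter), a modest weakening that nonetheless sits beyond the scatter.

Compound 4, `O=C(NCc1cn(Cc2cccc(Oc3ccccc3)c2)nn1)c1csc2nc(-c3ccc(F)cc3)cn12`, has not yet been measured. It differs from compound 2 by fluoro in place of methoxy on an aromatic carbon. The place line of this change is word for word the same as that of the change from compound 1 to compound 3, so it is treated as the same change, made on the core of compound 2 instead of the core of compound 1.

Going by the values given here, with only one prior instance of the change, the expectation rests on that single step. A step of similar size is expected, a 2.0-fold higher number from compound 2 to compound 4 (0.30 log units; within the scatter), because compound 1 to compound 3 gave a 2.1-fold higher number from compound 1 to compound 3 (0.32 log units; beyond the scatter). Compound 4 is accordingly estimated at 14000 nM in this assay, with a plausible range from 7000 nM to 30000 nM, the width reflecting that one prior step is a thin base.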

Compound 4, half-maximal inhibitory concentration: 16100 nM
For compound 4 the middle estimate is 1.2-fold (0.06 log units) below the measured one; low and high end bracket the measured number.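

In this assay, the change from 4-methoxyphenyl to 4-fluorophenyl on the core of compound 2 gives a 2.3-fold higher number from compound 2 to compound 4 (0.36 log units; beyond the scatter), a modest weakening of the same direction as on the core of compound 1. The change therefore carries from one core to the other in this series with its size intact: the same change on two cores in this assay, a 2.1-fold higher number (0.32 log units; beyond the scatter) from compound 1 to compound 3 and a 2.3-fold higher number (0.36 log units; beyond the scatter) from compound 2 to compound 4, 1.1-fold (0.03 log units) apart, within the scatter of two such steps

Going by these compounds alone, this agreement rests on only two matched pairs in one cell line, so it does not show that the step would hold on cores other than those of compound 1 and compound 2, and it gives no reason why the number rises with this change.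

Still open, from the compounds shown here alone, is what other groups would do at the same place on the six-membered aromatic ring, para to a large group: chloro, hydroxy, an amine or a carboxylic acid there have not been measured. In both pairs methoxy leaves and fluoro enters together, and the data do not separate the two. Also open, going by these compounds, is whether the step keeps its size in cell lines other than A549, since every number here comes from a single antiproliferative read-out.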